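The source may hold more compounds than are shown below. What is called first, only, known or untested is meant among the compounds shown, and "the series" means these compounds.

Measured compounds:
compound 1 `CCOC(=O)C1=C(N/C=N/c2cccnc2Cl)Nc2[nH]nc(C)c2C1c1ccc(N(C)C)cc1`: 4180 nM
compound 2 `CCOC(=O)C1=C(N/C=N/c2nnc(S(N)(=O)=O)s2)Nc2[nH]nc(C)c2C1c1ccc(N(C)C)cc1`: 34500 nM
compound 3 `CCOC(=O)C1=C(N/N=C(\C#N)C(N)=O)Nc2[nH]nc(C)c2C1c1ccc(N(C)C)cc1`: 50100 nM

In a functional assay on MCF7 cells (Homo sapiens) for inhibition, read by MTT assay, with a stated time of 48 h (on this read-out lower numbers stand for stronger inhibition and higher numbers for weaker inhibition), compound 1 gives the lowest number of the three, the strongest inhibition seen in this set. Compound 4 `CCOC(=O)C1=C(N/N=C(/C(=O)Br)c2ccc(Cl)cc2)Nc2[nH]nc(C)c2C1c1ccc(N(C)C)cc1` differs from compound 1 in one place: a group of 12 heavy atoms (8 carbon, 1 nitrogen, 1 oxygen, 1 chlorine, 1 bromine; one six-membered aromatic ring of carbon only) in place of a group of 9 heavy atoms (6 carbon, 2 nitrogen, 1 chlorine; one six-membered aromatic ring with 1 hetero atom), on an amine nitrogen. Two measured steps also exchange the group at this nitrogen, and both weakened inhibition: an 8.3-fold higher number from compound 1 to compound 2 (0.92 log units; beyond the scatter) and a 12-fold higher number from compound 1 to compound 3 (1.08 log units; beyond the scatter). The group entering compound 4 resembles neither replacement, but since both exchanges made at this nitrogen raised the number, a higher number in this assay is expected for compound 4 as well, with its size uncertain. Compound 4 is therefore estimated at 15000 nM, within 4000 nM to 60000 nM, an expected step of a 3.6-fold higher number from compound 1 to compound 4 (0.55 log units; beyond the scatter).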

Compound 4, half-maximal inhibitory concentration: 46300 nM
Compound 4: the middle estimate sits 3.1-fold (0.49 log units) below what was measured; low and high end bracket the measured number.
By their numbers in this assay, from the lowest: compound 1; then compounds 2, 4 and 3 (each within the scatter of the next).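

In this assay, a third kind of group on the amine nitrogen, this one with a six-membered aromatic ring of carbon only, again weakens inhibition, with an 11-fold higher number from compound 1 to compound 4 (1.04 log units; beyond the scatter). Three unlike groups now end up within the scatter of one another, with a 1.1-fold lower number from compound 3 to compound 4 (0.03 log units; within the scatter) and a 1.3-fold higher number from compound 2 to compound 4 (0.13 log units; within the scatter), so only the group of compound 1 stands apart from the rest. No evidence is available to explain this result. On these data alone, it remains open whether the chlorine in compound 1 is needed, and whether a plain pyridine or phenyl group would keep its lower number.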